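The compounds below may be only part of what the source reports. "The series", "measured", "known", "first", "only" and "open" are said of these compounds alone.

Compound 2 `O=C(Nc1ccc(Oc2ccnc3[nH]ccc23)c(F)c1)c1nccc(-c2cccc(Cl)c2)n1` and compound 1 `COc1ccc(-c2ccnc(C(=O)Nc3ccc(Oc4ccnc5[nH]ccc45)cc3)n2)cc1` share the same core, and both have been tested in a functional assay on PC-3 cells (Homo sapiens) for cytotoxicity, read by MTT assay, with a stated time of 72 h; a lower number here means a stronger inhibitor, a higher number a weaker inhibitor. Compound 2 gives 1380 nM, the lower of the two numbers, while compound 1 gives 17300 nM, a gap beyond the usual scatter. Compound 3 `COc1ccc(-c2ccnc(C(=O)Nc3ccc(Oc4ccnc5[nH]ccc45)c(F)c3)n2)cc1` has not yet been measured. It differs from compound 2 by 4-methoxyphenyl in place of 3-chlorophenyl on an aromatic carbon. Compound 1 carries the same 4-methoxyphenyl group and gives 17300 nM, so inhibition is expected to weaken. The step is expected to be a 6.5-fold higher number from compound 2 to compound 3 (0.81 log units; beyond the scatter). Compound 3 is estimated to give 9000 nM, between 3000 nM and 25000 nM.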

Compound 3, half-maximal inhibitory concentration: 14100 nM
Beside the measured number, compound 3's estimate is 1.6-fold (0.19 log units) below it; measured number inside the range.
By their numbers in this assay, from the lowest: compound 2; then compounds 3 and 1 (each within the scatter of the next).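

In this assay, 4-methoxyphenyl in place of 3-chlorophenyl on this aromatic carbon gives a 10-fold higher number from compound 2 to compound 3 (1.01 log units; beyond the scatter), so this position responds strongly to the change. Fluoro in place of hydrogen gives a 1.2-fold lower number from compound 1 to compound 3 (0.09 log units; within the scatter), which separates the two changes that the earlier pair carried together and shows no effect of fluoro beyond the scatter with 4-methoxyphenyl present. No measurement shown explains the size of the aryl step. Still open, as far as these compounds go, is whether fluoro matters alongside 3-chlorophenyl. From the compounds shown here alone, how a plain phenyl group or a carboxylic acid would fare at this position is also open.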